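Resolving the chain stereocentre of a cyclic ether agonist

A few compounds are considered here, and "the series" means these few. Any claim that something is new, unique, unknown or untested is made for them only; others in the source may bear on it.

Compound 3 `C[C@H](O[C@H]1CC[C@]2(CC1)COC(C)(C)C2)c1nc(-c2ccc(CS(C)(=O)=O)c(F)c2)no1` gives 430 nM in a functional assay on HEK293 cells for agonist activity at Glucose-dependent insulinotropic receptor (Homo sapiens), read by cAMP accumulation, with a stated time of 30 min (on this read-out higher numbers stand for an effect only at larger amounts of compound and lower numbers for an effect already at smaller amounts), the highest of the three numbers measured. Compound 1 `CC1(C)C[C@]2(CC[C@H](OCc3nc(-c4ccc(S(C)(=O)=O)c(F)c4)no3)CC2)CO1` gives 261 nM, which lies within the scatter of compound 3. Compound 2 `CC(O[C@H]1CC[C@]2(CC1)COC(C)(C)C2)c1nc(-c2ccc(CS(C)(=O)=O)c(F)c2)no1` gives 44 nM, a clearly lower number, and the step of a 9.8-fold higher number from compound 2 to compound 3 (0.99 log units; beyond the scatter) is the only one that bears on the present question, because the fact that one of compounds 2 and 3 is drawn with a defined configuration and the other without, at the place where they differ separates these two compounds at exactly the place where compound 4 differs from compound 3.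

Compound 4 `C[C@@H](O[C@H]1CC[C@]2(CC1)COC(C)(C)C2)c1nc(-c2ccc(CS(C)(=O)=O)c(F)c2)no1` keeps every atom and bond of compound 3; the difference is the two compounds have the same atoms and bonds and differ only in configuration as drawn: 2 of 3 stereo elements differ; a stereocentre at a saturated chain carbon is drawn S in compound 3 and R in compound 4; a stereocentre at a saturated ring carbon is drawn R in compound 3 and S in compound 4. Since compound 2 carries this chain stereocentre without a defined configuration and still reaches a much lower number than compound 3, the configuration drawn in compound 4 is expected to be the one that delivers that lower number, so a step of about a 17-fold lower number from compound 3 to compound 4 (1.24 log units; beyond the scatter) in the downward direction is expected. Compound 4 is therefore estimated at 25 nM, with a likely range from 10 nM to 70 nM.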

Compound 4, half-maximal effective concentration: 27 nM
Beside the measured number, compound 4's estimate is 1.1-fold (0.03 log units) below it, and the stated range covers the measured number.
By their numbers in this assay, from the lowest: compounds 4 and 2 (each within the scatter of the next); then compounds 1 and 3 (each within the scatter of the next).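

In this assay, configuration alone is enough to produce a 16-fold lower number from compound 3 to compound 4 (1.20 log units; beyond the scatter), as one plain fact shows: the fact that compounds 3 and 4 differ only in the configuration as drawn

Compound 2, which has no defined configuration at the chain stereocentre, shows a 1.6-fold lower number from compound 2 to compound 4 (0.21 log units; within the scatter), so the undefined and R forms cannot be told apart here: the fact that one of compounds 2 and 4 is drawn with a defined configuration and the other without, at the place where they differ

Until now, the S form was the only defined configuration at this chain stereocentre; compound 4 adds the R form, but the drawn label of the saturated ring carbon changes with it, so the step belongs to both differences together.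

Going by these compounds, it remains open whether the gap between the two configurations would persist if an ethyl group or a hydroxyl group replaced the methyl on this chain carbon. Compound 1 differs from the others in more than one place, so it cannot settle this.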